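Fluoro for Cyano on the Aromatic Ring

The compounds below may be only part of what the source reports. "The series", "measured", "known", "first", "only" and "open" are said of these compounds alone.

Two measured compounds share one core and differ only in the group on the aromatic ring. Compound 1 `Cc1cc(COc2ccc(Cl)cc2)nc(-c2ccccn2)n1` gives 251 nM in a functional assay on cells for antagonist activity at Free fatty acid receptor 1 (Homo sapiens), read by TR-FRET and inositol phosphate accumulation, with a stated time of 2 h; on this read-out lower numbers stand for stronger inhibition and higher numbers for weaker inhibition. Compound 2 `Cc1cc(COc2ccccc2C#N)nc(-c2ccccn2)n1` gives 10000 nM in this assay, the highest of the two numbers, and its gap to compound 1 lies well beyond the scatter. Compound 3 `Cc1cc(COc2ccccc2F)nc(-c2ccccn2)n1` takes one step from compound 2: fluoro in place of cyano on an aromatic carbon, ortho to a large group. Going by the values given here, no measured step of this kind exists here, so the expectation rests on the change alone: the number is expected to fall moderately, toward stronger inhibition, a 2.5-fold lower number from compound 2 to compound 3 (0.40 log units; beyond the scatter). Compound 3 is estimated at 4000 nM, within 1000 nM to 15000 nM.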

Compound 3, half-maximal inhibitory concentration: 398 nM
Beside the measured number, compound 3's estimate is 10-fold (1.00 log units) above it; the whole stated range lies above it.
By their numbers in this assay, from the lowest: compounds 1 and 3 (each within the scatter of the next); then compound 2.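

On this aromatic carbon, ortho to a large group, the choice of group matters greatly: in this assay, fluoro in place of cyano gives a 25-fold lower number from compound 2 to compound 3 (1.40 log units; beyond the scatter), so the weak result of compound 2 does not extend to every group at this place. The 2-fluorophenyl and 4-chlorophenyl compounds cannot be told apart, with a 1.6-fold higher number from compound 1 to compound 3 (0.20 log units; within the scatter) between them. Nothing available explains the size of the cyano-to-fluoro step. Going by these compounds, it remains open how an amine or a methoxy group on the same carbon would read.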